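Swapping the Group on the Carbonyl at the Ring Nitrogen

The compounds below may be only part of what the source reports. "The series", "measured", "known", "first", "only" and "open" are said of these compounds alone.

Compound 1, `CC(C)(C)c1cc(NC(=O)[C@@H]2CCCCN2CC2CC2)no1`: 0.15 h
Compound 2, `CC(C)(C)c1cc(NC(=O)[C@@H]2CCCCN2C(=O)C2CCOCC2)no1`: > 2 h

In an ADME assay (liver) for metabolic stability, with Liver microsome (Homo sapiens) as the target, read by LC-MS, using microsomes and NADPH, tested at 1 uM (a higher number here means that the compound lasts longer, a lower number that the compound disappears faster), compound 1 gives 0.15 h. For compound 2 the reading of > 2 h is a limit of the assay and not a number. Going by the values given here, the single measured step, an at least 13-fold higher number from compound 1 to compound 2 (1.12 log units; beyond the scatter), is large, and it ends at the limit of > 2 h in this assay, at which 1 of the 2 values shown sits. Compound 3, `CC(=O)N1CCN(C(=O)N2CCCC[C@H]2C(=O)Nc2cc(C(C)(C)C)on2)CC1`, keeps the carbonyl on the amide-type nitrogen in the ring and differs from compound 2 only in 4-acetylpiperazin-1-yl in place of oxan-4-yl on a carbonyl carbon. Among the compounds with values here, no measured step covers this exchange; the one measured step concerns the group on the ring nitrogen itself, and it bears on compound 3 only in that compound 2 already stands at the limit. Compound 3 is therefore expected to remain near that limit, with a step that the limit leaves unreadable from compound 2 to compound 3 expected to be no more than the scatter. Compound 3 is estimated at 2.5 h, within 1 h to 6 h.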

Compound 3, half-life: > 2 h
Compound 3: only a limit was reported; the forecaster's own chance of this, stated with the estimate: 60%; the middle value is on the limit's open side.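

In this assay compound 3 gives > 2 h, which is a limit of the assay and not a number. Compound 2 also stands at a limit, so no step between compound 2 and compound 3 can be read: the limit of > 2 h in this assay, at which 2 of the 3 values shown sit.

On these data alone, whether compound 2 or compound 3 lasts longer in this assay remains open.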